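The compounds below may be only part of what the source reports. "The series", "measured", "known", "first", "only" and "open" are said of these compounds alone.

Compound 1 `CCCC(=O)Nc1ccc(N2CCN(c3ccc(OC[C@@H]4CO[C@@](Cn5cncn5)(c5ccc(Cl)cc5Cl)O4)cc3)CC2)cc1` and compound 2 `O=C(CC1CCOCC1)Nc1ccc(N2CCN(c3ccc(OC[C@@H]4CO[C@@](Cn5cncn5)(c5ccc(Cl)cc5Cl)O4)cc3)CC2)cc1` share one core and differ only on a saturated chain carbon bound to a carbonyl carbon. In a toxicity assay on L02 cells (Homo sapiens) for inhibition, read by MTT assay, with a stated time of 48 h (on this read-out lower numbers stand for stronger inhibition and higher numbers for weaker inhibition), compound 1 gives a value that is a limit of the assay, > 50000 nM. In this assay compound 2 likewise gives only a limit, > 50000 nM. The step from one to the other, a step that the two limits leave unreadable from compound 1 to compound 2, therefore cannot be sized; both values sit at the limit of > 50000 nM in this assay, at which 2 of the 2 values shown sit. Compound 2 thus stands at the assay limit, with no number that places it above or below compound 1.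

Compound 3 `O=C(CCCCc1ccccc1)Nc1ccc(N2CCN(c3ccc(OC[C@@H]4CO[C@@](Cn5cncn5)(c5ccc(Cl)cc5Cl)O4)cc3)CC2)cc1` carries the next change: 3-phenylpropyl in place of oxan-4-yl on a saturated chain carbon bound to a carbonyl carbon. Among the measured compounds shown here, nothing among the measured steps can be read in size, so no direction can be drawn from them; the only bearing is that both measured compounds rest at the limit, as the limit of > 50000 nM in this assay, at which 2 of the 2 values shown sit, records. Compound 3 is accordingly expected to remain in the same region, with a step that the limit leaves unreadable from compound 2 to compound 3 estimated as not separating it from compound 2 beyond the scatter. Compound 3 is estimated at 80000 nM, within 30000 nM to 300000 nM, most likely reported again as a limit.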

Compound 3, half-maximal inhibitory concentration: > 50000 nM
Compound 3: a limit, no number (the forecaster's own chance of this, stated with the estimate: 85%); the middle value is on the limit's open side.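

In this assay compound 3 gives > 50000 nM, again a limit of the assay and not a number. Among the compounds shown here, no step among compound 1, compound 2 and compound 3 can be read, as all three rest at the same limit: the limit of > 50000 nM in this assay, at which 3 of the 3 values shown sit. The compounds shown leave open whether these three differ at all in this assay.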